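Replacing the Side Chain of Compound 2

The compounds below may be only part of what the source reports. "The series", "measured", "known", "first", "only" and "open" are said of these compounds alone.

Going by the values given here, in a functional assay on the whole organism with Mus musculus as the target, in the rotarod test (a lower number here means that less compound is needed, a higher number that more compound is needed for the effect), compound 2 `CC(NC(=O)CN)C(=O)N(C)c1ccc(Cl)cc1C(=O)c1ccccc1Cl` gives 8.5 mg/kg, the only true number available so far. Compound 1 `CC(=O)NCC(=O)Nc1ccc(Cl)cc1C(=O)c1ccccc1` stands at > 100 mg/kg in this assay, and this value is a limit, not a number.

Compound 3 `CCCC(=O)NCC(=O)N(C)c1ccc(Cl)cc1C(=O)c1ccccc1Cl` has ((propylcarbonyl)amino)methyl in place of 1-(((aminomethyl)carbonyl)amino)ethyl on a carbonyl carbon. The aminomethyl end of the chain is therefore gone. Among the compounds with values here, no two measured compounds differ in just one place, so no measured step shows how large such a change might be. Compound 2 at 8.5 mg/kg is the only anchor, and a step beyond the usual scatter towards a higher dose seems likely, though this remains a judgement. The expected shift is a 4.7-fold higher number from compound 2 to compound 3 (0.67 log units; beyond the scatter). For compound 3, the estimated value in this assay is 40 mg/kg, with an expected range of 10 mg/kg to 150 mg/kg.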

Compound 3, dose for half-maximal effect: 55.2 mg/kg
Estimate against measurement, compound 3: 1.4-fold (0.14 log units) below; low and high end bracket the measured number.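

Going by these compounds alone, this is the first step that can be read between two measured compounds: in this assay, putting ((propylcarbonyl)amino)methyl in place of 1-(((aminomethyl)carbonyl)amino)ethyl on a carbonyl carbon gives a 6.5-fold higher number from compound 2 to compound 3 (0.81 log units; beyond the scatter). The side chain at this place therefore matters to the dose needed, even though both groups hold 7 heavy atoms. The new compound still gives a true number, which not every compound in this small set does: the limit of > 100 mg/kg in this assay, at which 1 of the 3 values shown sits.

The swap alters the chain at more than one point, removing the aminomethyl end and the branch of the ethyl group while adding the propyl group, so this single step cannot show which alteration carries the shift. Going by these compounds, it also remains open how the dose would respond to a chain that keeps the amine without the branch, to a longer chain, or to a carboxylic acid at the chain's end.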